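A few compounds are considered here, and "the series" means these few. Any claim that something is new, unique, unknown or untested is made for them only; others in the source may bear on it.

Working notes on the series. Compound 1 `COc1cc(NC(=O)Nc2ccc(Oc3ccccc3)cc2)ccc1C(=O)NCCCN1CCCCC1` in an assay on CHO cells for binding affinity to melanin-concentrating hormone receptor 2 (Homo sapiens), read by radioligand binding (on this read-out higher numbers stand for weaker inhibition and lower numbers for stronger inhibition), gives 10000 nM. Compound 2 `COc1cc(NC(=O)Nc2cccc(Oc3ccccc3)c2)ccc1C(=O)NCCCN1CCCCC1` in this assay returns only a limit of the assay, > 100000 nM. This is the case described by the limit of > 100000 nM in this assay, at which 1 of the 2 values shown sits. Compound 3 `COc1cc(NC(=O)Nc2cccc(Nc3ccccc3)c2)ccc1C(=O)NCCCN1CCCCC1` has not yet been measured in this assay. From compound 2 to compound 3 the change is anilino in place of phenoxy on an aromatic carbon. Among the measured compounds shown here, no measured pair carries this change, so its size cannot be read from the numbers; with compound 2 standing at a limit, no step beyond the scatter is expected in this assay. Compound 3 is estimated at 100000 nM, with a range of 20000 nM to 300000 nM. The expected step is a number no higher from compound 2 to compound 3 (the limit leaves the size open).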

Compound 3, half-maximal inhibitory concentration: 10000 nM
Compound 3: the middle estimate sits 10-fold (1.00 log units) above what was measured, and the stated range ends above it.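

At this aromatic carbon, meta to a large group, anilino in place of phenoxy gives an at least 10-fold lower number from compound 2 to compound 3 (1.00 log units; beyond the scatter) in this assay. This first measured pair for the change shows that it can move the number beyond the scatter. Compound 2 stands at a limit of the assay, so the step is only a bound and its full size stays unread: the limit of > 100000 nM in this assay, at which 1 of the 3 values shown sits.

Still open, from the compounds shown here alone, is whether benzyl or benzoyl at this carbon gives a number like that of anilino. A single pair also leaves open whether the change carries over to other positions on the ring.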